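The source may report more compounds than this note shows. Statements on the series, on what has been measured and on what is new or still open speak of the compounds shown alone.

Among the measured compounds shown here, compound 2 `CC1(C)CC(NC(=O)NCc2ccccc2)c2cc(Cl)ccc2O1`, tested in a functional assay on U-373MG ATCC cells (Homo sapiens) for inhibition, read by MTT assay, with a stated time of 72 h (on this read-out lower numbers stand for stronger inhibition and higher numbers for weaker inhibition), gives 66000 nM, the highest of the three numbers measured so far. Its nearest neighbour is compound 1 `CC1(C)CC(NC(=O)NCc2ccccc2)c2cc(Br)ccc2O1`, which in this assay gives 27000 nM; the step of a 2.4-fold higher number from compound 1 to compound 2 (0.39 log units; beyond the scatter). Furthest away is compound 3 `CC1(C)CC(NC(=S)Nc2cccc(Cl)c2)c2cc(Br)ccc2O1`, which in this assay gives 8000 nM. Compound 4 `CCOC(=O)NC1CC(C)(C)Oc2ccc(Cl)cc21` differs from compound 2 in one place: ethoxy in place of benzylamino on a carbonyl carbon. For the measured compounds named here, none of the measured steps touches the carbonyl carbon or its benzylamino group, so nothing measured bears directly on this change; the only measured step concerns a halogen on the aromatic ring. With no guide, the expected step of a 1.4-fold higher number from compound 2 to compound 4 (0.13 log units; within the scatter) is small. For compound 4 in this assay the estimate is 90000 nM, within a range of 25000 nM to 300000 nM.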

Compound 4, half-maximal inhibitory concentration: > 100000 nM
Compound 4: only a limit was reported (the forecaster's own chance of this, stated with the estimate: 40%); middle value at least 1.1-fold (0.04 log units) away from the limit.
By their numbers in this assay, from the lowest: compound 3; then compound 1; then compound 2. At a limit, above all of these: compound 4.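

Replacing benzylamino with ethoxy on the carbonyl carbon, the first change measured at this place, gives an at least 1.5-fold higher number from compound 2 to compound 4 (0.18 log units; that floor lies within the scatter). Compound 4 gives a limit and not a number: the limit of > 100000 nM in this assay, at which 1 of the 4 values shown sits. So in this assay this change brings no sign of stronger inhibition, though the floor of the step alone does not establish a real loss. Still open, as far as these compounds go, is which part of benzylamino counts, the aromatic ring or the nitrogen. An ethylamino group on the same carbonyl carbon would help separate the two.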